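The source may report more compounds than this note shows. Statements on the series, on what has been measured and on what is new or still open speak of the compounds shown alone.

Compound 2 `CCN1CCN(CC(=O)NC2(c3ccc(Cl)c(Cl)c3)C(=O)Nc3cc(Cl)cc(Cl)c32)CC1=O` is the weaker of the two compounds measured in an in vitro functional assay on CHO-CREluc cells for antagonist activity at growth hormone secretagogue receptor type 1 (Homo sapiens), read by a luciferase reporter, with a stated time of 4 h; a higher number here means a weaker inhibitor, a lower number a stronger inhibitor: compound 2 gives 2780 nM, whereas compound 1 `CN(C)C1CCN(CC(=O)NC2(c3ccc(Cl)c(Cl)c3)C(=O)Nc3cc(Cl)cc(Cl)c32)CC1` gives 239 nM. For the measured compounds named here, the only change between them, 4-ethyl-3-oxopiperazin-1-yl in place of 4-(dimethylamino)piperidin-1-yl on a saturated chain carbon bound to a carbonyl carbon, produced a 12-fold higher number from compound 1 to compound 2 (1.07 log units; beyond the scatter). Compound 3 `CCN1CCCC(CC(=O)NC2(c3ccc(Cl)c(Cl)c3)C(=O)Nc3cc(Cl)cc(Cl)c32)C1` takes the next step: 1-ethylpiperidin-3-yl in place of 4-ethyl-3-oxopiperazin-1-yl on a saturated chain carbon bound to a carbonyl carbon. Going by the values given here, this brings back a ring amine without the ring carbonyl, so the one measured step that bears on it is the step from compound 1 to compound 2, which was large and went toward a weaker inhibitor. Undoing part of that change is therefore expected to move this assay back toward a lower number, as a 4.6-fold lower number from compound 2 to compound 3 (0.67 log units; beyond the scatter). Compound 3 is accordingly estimated at 600 nM, with a range from 200 nM to 2000 nM.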

Compound 3, half-maximal inhibitory concentration: 47 nM
Compound 3: middle estimate off by 13-fold (1.11 log units), on the high side, and the stated range ends above it.
By their numbers in this assay, from the lowest: compound 3; then compound 1; then compound 2.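

In this assay, 1-ethylpiperidin-3-yl in place of 4-ethyl-3-oxopiperazin-1-yl on a saturated chain carbon bound to a carbonyl carbon gives a 59-fold lower number from compound 2 to compound 3 (1.77 log units; beyond the scatter), so the loss seen with the oxopiperazine is more than recovered. The same group in place of 4-(dimethylamino)piperidin-1-yl gives a 5.1-fold lower number from compound 1 to compound 3 (0.71 log units; beyond the scatter), which shows that compound 1 did not mark the lowest number reachable at this place and makes compound 3 the strongest inhibitor of the three. Nothing available explains why these groups differ so much. The compounds shown leave open which feature of 1-ethylpiperidin-3-yl carries the gain, as each step changes the whole group at once. Close relatives such as 1-methylpiperidin-3-yl, 1-ethylpiperidin-4-yl or 1-ethylpyrrolidin-3-yl would separate the ethyl group, the point of attachment and the ring size.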